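Series notes: the step from compound 1 to compound 4

A few compounds are considered here, and "the series" means these few. Any claim that something is new, unique, unknown or untested is made for them only; others in the source may bear on it.

Compound 1 `COc1ccc2c(c1)c(/C=N/O)cn2Cc1cn([C@@H]2O[C@H](COC(C)=O)[C@@H](OC(C)=O)[C@H](OC(C)=O)[C@H]2OC(C)=O)nn1` is the starting point. In a functional assay on HeLa cells (Homo sapiens) for cytotoxicity, read by sulforhodamine B assay, with a stated time of 48 h (a lower number here means a stronger inhibitor, a higher number a weaker inhibitor), compound 1 gives > 200000 nM, which is a limit of the assay and not a number. Compound 2 `CC(=O)OC[C@H]1O[C@@H](n2cc(Cn3cc(C(C)=O)c4ccccc43)nn2)[C@H](OC(C)=O)[C@@H](OC(C)=O)[C@@H]1OC(C)=O` gives in this assay > 200000 nM, again a limit. Compound 3 `CC(=O)OC[C@H]1O[C@@H](n2cc(Cn3cc(/C=C/C(=O)c4cccnc4)c4ccccc43)nn2)[C@H](OC(C)=O)[C@@H](OC(C)=O)[C@@H]1OC(C)=O` gives in this assay > 200000 nM, also a limit. Going by the values given here, the one measured step between neighbours, a step that the two limits leave unreadable from compound 2 to compound 3, has no readable size, and the common picture is the limit of > 200000 nM in this assay, at which 3 of the 3 values shown sit. Compound 1 therefore stands with the other two at the limit, and no ordering among the three can be drawn.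

Compound 4 `COc1ccc2c(c1)c(/C=C1/C(=O)Nc3ccc(F)cc31)cn2Cc1cn([C@@H]2O[C@H](COC(C)=O)[C@@H](OC(C)=O)[C@H](OC(C)=O)[C@H]2OC(C)=O)nn1` differs from compound 1 as follows: a group of 12 heavy atoms (9 carbon, 1 nitrogen, 1 oxygen, 1 fluorine; one five-membered non-aromatic ring with 1 hetero atom, one six-membered aromatic ring of carbon only) in place of a group of 3 heavy atoms (1 carbon, 1 nitrogen, 1 oxygen; no ring), on an aromatic carbon. Among the compounds with values here, no measured step touches this exchange; the change from compound 2 to compound 3 sits at another position and is itself unreadable. Nothing in the data gives a direction in this assay for the group that enters. The estimated step of an at least 4.0-fold lower number from compound 1 to compound 4 (0.60 log units; beyond the scatter) is therefore set with wide uncertainty. The estimated value for compound 4 in this assay is 50000 nM. For compound 4 the expected range runs from 5000 nM to 200000 nM, with a real chance that only a limit is reported again.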

Compound 4, half-maximal inhibitory concentration: > 200000 nM
Compound 4: only a limit was reported; the forecaster's own chance of this, stated with the estimate: 50%; at least 4.0-fold (0.60 log units) between middle value and limit.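

In this assay, going by these compounds alone, compound 4 gives > 200000 nM, which is a limit and not a number, so no step from compound 1 to compound 4 can be read. The common picture remains: the limit of > 200000 nM in this assay, at which 4 of the 4 values shown sit.

The compounds shown leave open whether any exchange on the shared core gives a number rather than a limit in this assay.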